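Isopropyl for 2-methoxyethyl at the aromatic nitrogen

A few compounds are considered here, and "the series" means these few. Any claim that something is new, unique, unknown or untested is made for them only; others in the source may bear on it.

Values in a functional assay on FaDu cells (Homo sapiens) for cytotoxicity, read by MTT assay, with a stated time of 72 h; a higher number here means that more compound is tolerated, a lower number that less compound is tolerated:
- compound 1 `COc1ncc(NC(=O)C(=O)c2cn(C(C)C)c3ccccc23)cn1`: 171 nM
- compound 2 `CC(C)n1cc(C(=O)C(=O)Nc2cccnc2)c2ccccc21`: > 10000 nM, a limit of the assay
- compound 3 `COCCn1cc(C(=O)C(=O)Nc2ccnc(OC)c2)c2ccccc21`: 235 nM

Within the data shown here, compound 3 lies within the scatter of compound 1, and these two are the only actual numbers so far, the third value being a limit. Compound 4 `COc1cc(NC(=O)C(=O)c2cn(C(C)C)c3ccccc23)ccn1` keeps the rest of compound 3 and takes isopropyl in place of 2-methoxyethyl on an aromatic nitrogen.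

Among the measured compounds shown here, no measured step touches that nitrogen. For the measured compounds named here, the single measured step, an at least 58-fold higher number from compound 1 to compound 2 (1.76 log units; beyond the scatter), is large and beyond the scatter, but it swaps pyridin-3-yl in place of 2-methoxypyrimidin-5-yl on an amide-type nitrogen, a place left unchanged here. It bears only as a warning that values in this series can move sharply, which widens the range. Closer to the point, compound 1 already carries isopropyl, and compound 1 at 171 nM lies within the scatter of compound 3 at 235 nM. No step beyond the scatter is therefore expected in this assay, and no direction is favoured. The expected step is a 1.2-fold lower number from compound 3 to compound 4 (0.07 log units; within the scatter). The estimate for compound 4 is 200 nM, with an expected range from 60 nM to 800 nM.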

Compound 4, concentration lethal to 50% of the cells: 1750 nM
Beside the measured number, compound 4's estimate is 8.8-fold (0.94 log units) below it, and the stated range ends below it.
By their numbers in this assay, from the lowest: compounds 1 and 3 (each within the scatter of the next); then compound 4. At a limit, above all of these: compound 2.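

In this assay, among these compounds, the first measured step at the aromatic nitrogen shows that this position matters: with the 2-methoxypyridin-4-yl group held constant, isopropyl in place of 2-methoxyethyl is tolerated far less cytotoxically, with a step beyond the scatter (a 7.4-fold higher number from compound 3 to compound 4 (0.87 log units; beyond the scatter)). The closeness of compound 1 and compound 3 therefore did not mean that the group on this nitrogen is silent, and with isopropyl held constant the group on the amide-type nitrogen also moves the number by a large step (a 10-fold higher number from compound 1 to compound 4 (1.01 log units; beyond the scatter)). Compound 2 carries a limit and not a number, so the remaining step is a bound and gives no measured size: (an at least 5.7-fold lower number from compound 2 to compound 4 (0.75 log units; beyond the scatter)); the limit concerned is this one: (the limit of > 10000 nM in this assay, at which 1 of the 4 values shown sits).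

A single pair cannot tell whether the step follows the oxygen of 2-methoxyethyl, the chain as a whole or the branching of isopropyl, and a 2-hydroxyethyl, 3-methoxypropyl or unbranched propyl group on this nitrogen would separate these readings. On these data alone, it also stays open whether the same exchange gives a step of similar size alongside 2-methoxypyrimidin-5-yl on the amide-type nitrogen.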